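A few compounds are considered here, and "the series" means these few. Any claim that something is new, unique, unknown or untested is made for them only; others in the source may bear on it.

In a functional assay on MT4 cells (Homo sapiens) for cytotoxicity (a higher number here means that more compound is tolerated, a lower number that less compound is tolerated), three compounds sharing one core have been measured so far. Compound 1 `CCC(c1ccccc1)c1cc(O)nc(SC(C)C)n1` gives > 200000 nM, which is a limit of the assay and not a number. Compound 2 `CCC(C)Sc1nc(O)cc(C(CC)c2ccccc2)n1` gives > 200000 nM, again a limit. Going by the values given here, compound 3 `CCC(c1ccccc1)c1cc(O)nc(SC2CCCCC2)n1` gives 51000 nM, the only actual number of the three. Changing the group on the sulfur to cyclohexyl produced an at least 3.9-fold lower number from compound 1 to compound 3 (0.59 log units; beyond the scatter) and also an at least 3.9-fold lower number from compound 2 to compound 3 (0.59 log units; beyond the scatter).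

Compound 4 `CCC(c1cc(O)nc(SC2CCCCC2)n1)c1c(F)cccc1F` keeps that cyclohexyl and changes the other end of the molecule: 2,6-difluorophenyl in place of phenyl on a saturated chain carbon bound to an aromatic carbon and a saturated chain carbon. The new 2,6-difluorophenyl sits on a saturated chain carbon bound to an aromatic carbon and a saturated chain carbon. Both measured steps concern the group on the sulfur, so neither tests this place directly. The best anchor is therefore compound 3 at 51000 nM, and no shift beyond the scatter is expected. The estimated change is a 1.1-fold lower number from compound 3 to compound 4 (0.05 log units; within the scatter). For compound 4 the expected value is 45000 nM, within an estimated range of 16000 nM to 130000 nM.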

Compound 4, half-maximal cytotoxic concentration: > 200000 nM
Compound 4: a limit, no number (the forecaster's own chance of this, stated with the estimate: 15%); middle value at least 4.4-fold (0.64 log units) from the limit.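

Until now, every readable step concerned the group on the sulfur. Compound 4 gives the first readout from the other end of the molecule: in this assay, 2,6-difluorophenyl in place of phenyl brings an at least 3.9-fold higher number from compound 3 to compound 4 (0.59 log units; beyond the scatter), the opposite direction to the drop seen when cyclohexyl went onto the sulfur. Compound 4 gives > 200000 nM, a limit of the assay and not a number, so the step shows a direction and a minimum size, but its full size stays unknown: the limit of > 200000 nM in this assay, at which 3 of the 4 values shown sit.

The compounds shown do not tell whether both fluorines are needed, or whether a phenyl carrying a single fluorine, a chlorine or a methoxy group would shift the number too. Also open, on these data alone, is how 2,6-difluorophenyl behaves with a group other than cyclohexyl on the sulfur, such as a benzyl.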